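Replacing a methoxymethoxy group on a chalcone core

A few compounds are considered here, and "the series" means these few. Any claim that something is new, unique, unknown or untested is made for them only; others in the source may bear on it.

The study compares four compounds in a functional assay on HeLa cells (Homo sapiens) for cytotoxicity, read by resazurin assay, with a stated time of 72 h; a higher number here means a weaker inhibitor, a lower number a stronger inhibitor. Compound 1 `COc1cc(OC)c(C(C)=O)c(OC)c1` gives 3800 nM, while compound 2 `COCOc1cc(OC)cc(OC)c1C(C)=O` gives 14000 nM. The change between them is hydrogen in place of methoxy on a saturated chain carbon bound to an oxygen on an aromatic ring, and it produced a 3.7-fold lower number from compound 2 to compound 1 (0.57 log units; beyond the scatter). Compound 3 `COCOc1cc(OCOC)c(C(=O)/C=C/c2ccccc2)c(OCOC)c1` gives 11500 nM in this assay; its core differs from that of compound 2, but that difference is not broken down here. Compound 4 `COCOc1cc(OC)c(C(=O)/C=C/c2ccccc2)c(OCOC)c1` carries the same change relative to compound 3: hydrogen in place of methoxy on a saturated chain carbon bound to an oxygen on an aromatic ring. Because compound 2 to compound 1 gave a 3.7-fold lower number from compound 2 to compound 1 (0.57 log units; beyond the scatter), the step for compound 4 is expected to run in the same direction, as a 2.6-fold lower number from compound 3 to compound 4 (0.41 log units; beyond the scatter), though it rests on a single earlier step. Compound 4 is therefore estimated at 4500 nM in this assay, within a range of 2000 nM to 10000 nM.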

Compound 4, half-maximal inhibitory concentration: 9700 nM
Beside the measured number, compound 4's estimate is 2.2-fold (0.33 log units) below it, within the range that was stated.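

In this assay, the change from methoxymethoxy to methoxy gave a 1.2-fold lower number from compound 3 to compound 4 (0.07 log units; within the scatter), and its size did not carry over from one core to the other: the same change on two cores in this assay, a 3.7-fold lower number (0.57 log units; beyond the scatter) from compound 2 to compound 1 and a 1.2-fold lower number (0.07 log units; within the scatter) from compound 3 to compound 4, 3.1-fold (0.49 log units) apart, beyond the scatter of two such steps The larger step seen on the core of compound 2 therefore cannot be taken as a fixed increment for this change in the series. Among these compounds, with only one pair on each core, the comparison does not show which feature of the cores goes with the gap, or how the change would behave on any further core.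

The compounds shown carry only methoxy or methoxymethoxy at the site of the change. On these data alone, how a hydroxyl group, a longer chain such as ethoxy, or an amine would read there in this assay remains open.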